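A Single Trifluoromethoxy Group in Place of Two Chlorines

This account rests on a few compounds, and the source may have more. Where it says the series, first, only, none or still open, it means among the compounds named here.

The three measured compounds share one core and differ only in the aryl group on a saturated chain carbon bound to an oxygen on a saturated carbon. In a functional assay on cells for inhibition of growth hormone secretagogue receptor type 1 (Homo sapiens), read by FLIPR and calcium flux (a lower number here means that less compound is needed, a higher number that more compound is needed for the effect), compound 1 `CC(C)(N)C(=O)N[C@H](COCc1ccccc1Cl)c1nnnn1CCOC(=O)NCCCCO` gives 0.45 nM. In this assay compound 2 `CC(C)(N)C(=O)N[C@H](COCc1cc(Cl)cc(Cl)c1)c1nnnn1CCOC(=O)NCCCCO` gives 6.75 nM, and compound 3 `CC(C)(N)C(=O)N[C@H](COCc1cc(C(F)(F)F)cc(C(F)(F)F)c1)c1nnnn1CCOC(=O)NCCCCO` gives 34 nM. Compound 2 therefore stands second highest of the three numbers, with compound 3 above it and compound 1 well below it. Going by the values given here, the only step recorded between two measured compounds is a 15-fold higher number from compound 1 to compound 2 (1.18 log units; beyond the scatter).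

Compound 4 `CC(C)(N)C(=O)N[C@H](COCc1cccc(OC(F)(F)F)c1)c1nnnn1CCOC(=O)NCCCCO` differs from compound 2 in one place: 3-(trifluoromethoxy)phenyl in place of 3,5-dichlorophenyl on a saturated chain carbon bound to an oxygen on a saturated carbon. Among the compounds with values here, no measured step covers this exchange directly. The step from compound 1 to compound 2 shows that the substitution pattern on this ring can shift the number strongly, and the values of compound 2 and compound 3 show that the number rises further when both chlorines give way to a different pair of groups. Within the data shown here, compound 4 carries only one group, and the direction of its change cannot be read from these data, so the number is expected to stay near that of compound 2. Compound 4 is estimated at 5 nM, with a range from 1.2 nM to 20 nM. The expected step is a 1.4-fold lower number from compound 2 to compound 4 (0.13 log units; within the scatter), which lies within the scatter.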

Compound 4, half-maximal effective concentration: 3.1 nM
Compound 4: middle estimate off by 1.6-fold (0.21 log units), on the high side, within the range that was stated.
By their numbers in this assay, from the lowest: compound 1; then compound 4; then compound 2; then compound 3.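

In this assay, the exchange of 3,5-dichlorophenyl for 3-(trifluoromethoxy)phenyl gives a 2.2-fold lower number from compound 2 to compound 4 (0.34 log units; beyond the scatter), so a modest move downward is possible at this position even with a group of more heavy atoms than the one it replaces. The earlier compounds shown here showed only rising numbers as the aryl group moved away from 2-chlorophenyl, and compound 4 now places a ring with a single group, a trifluoromethoxy, in the gap between compound 1 and compound 2. Even so, 2-chlorophenyl keeps its lead, with a 6.9-fold higher number from compound 1 to compound 4 (0.84 log units; beyond the scatter), and no measured information on the compounds explains either step.

Compound 4 differs from compound 2 in two ways at once, losing the two chlorines and gaining the trifluoromethoxy group, so these compounds cannot separate the effect of having one group on the ring from the effect of that particular group. As far as these compounds go, how the number would respond to an unsubstituted phenyl ring, or to a methoxy group or a nitrile in place of the trifluoromethoxy group, remains open.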